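This account rests on a few compounds, and the source may have more. Where it says the series, first, only, none or still open, it means among the compounds named here.

Measured so far in a functional assay on JAR cells (Homo sapiens) for inhibition, read by MTT assay, with a stated time of 72 h, tested at 10 uM; a higher number here means more inhibition at the concentration tested (going by the name of the read-out), a lower number less inhibition:
compound 1, `CCOC(=O)C1=C(Nc2ccccc2)S/C(=C\c2cc(OC)ccc2OC)C1=O`: 38.1%
compound 2, `CCOC(=O)C1=C(Nc2ccccc2)S/C(=C\c2ccccc2O)C1=O`: 89.4%
compound 3, `CCOC(=O)C1=C(Nc2ccccc2)S/C(=C\c2ccccc2C(F)(F)F)C1=O`: 29%

Compound 2 holds the highest number of the three; compound 1 sits a number 60.4 percentage points lower from compound 2 to compound 3 (beyond the scatter) apart from it only in its own way, the nearest to it, while compound 3 stands furthest. Among the compounds with values here, the one single-point step on record is a number 60.4 percentage points lower from compound 2 to compound 3 (beyond the scatter), where a trifluoromethyl stands in place of the hydroxy on an aromatic carbon. Compound 4, `CCOC(=O)C1=C(Nc2ccccc2)S/C(=C\c2cc3ncccc3[nH]2)C1=O`, has not yet been measured in this assay. Its change from compound 2 is a group of 9 heavy atoms (7 carbon, 2 nitrogen; one five-membered aromatic ring with 1 hetero atom, one six-membered aromatic ring with 1 hetero atom) in place of a group of 7 heavy atoms (6 carbon, 1 oxygen; one six-membered aromatic ring of carbon only), on a double-bonded chain carbon bound to a double-bonded ring carbon. That step bears on the recorded one only loosely: the hydroxy leaves again, but the entering group, with its five-membered aromatic ring with 1 hetero atom and six-membered aromatic ring with 1 hetero atom, still carries 1 hydrogen-bond donor and 1 hydrogen-bond acceptor. A drop is expected for compound 4, smaller than a number 60.4 percentage points lower from compound 2 to compound 3 (beyond the scatter) but beyond the scatter, giving an estimated a number 34.4 percentage points lower from compound 2 to compound 4 (beyond the scatter). Compound 4 is therefore estimated at 55%, within 20% to 90%.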

Compound 4, a percentage reported as inhibition, at one concentration (the size of the read-out at that concentration, not a potency): 74.8%
The estimate for compound 4 lay 19.8 percentage points below the measured number, within the range that was stated.
By their numbers in this assay, from the lowest: compounds 3 and 1 (each within the scatter of the next); then compound 4; then compound 2.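

In this assay, within the data shown here, the 2-hydroxyphenyl on the double-bonded chain carbon bound to a double-bonded ring carbon gives way to the larger group with two aromatic rings, and the result is a number 14.6 percentage points lower from compound 2 to compound 4 (beyond the scatter), a modest step where the only earlier single change here, a number 60.4 percentage points lower from compound 2 to compound 3 (beyond the scatter), was large. The hydroxy can therefore leave this place with much of the inhibition kept, as compound 4 still gives 74.8%, so the earlier trifluoromethyl step does not speak for every replacement of that group. No evidence on hand accounts for the difference in size between these two steps.

On these data alone, whether the shared count of hydrogen-bond donors and acceptors matters remains open, as does the contribution of each of the two rings in the entering group. An amine or a carboxylic acid in place of the hydroxy on the phenyl ring also remains untested among the compounds shown here.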